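Halogen furans on a cyanoacrylamide: from chloro to bromo

The source may report more compounds than this note shows. Statements on the series, on what has been measured and on what is new or still open speak of the compounds shown alone.

Three compounds share one core and differ only in the aromatic ring on the double-bonded chain carbon. In a functional assay on SMA cells (Homo sapiens) for inhibition, read by MTT assay, with a stated time of 72 h (a higher number here means a weaker inhibitor of growth, a lower number a stronger inhibitor of growth), compound 1 `COc1ccc(CNC(=O)/C(C#N)=C/c2ccc[nH]2)cc1` gives only a limit of the assay, > 50000 nM. Compound 2 `COc1ccc(CNC(=O)/C(C#N)=C/c2ccc(C)o2)cc1` gives 69000 nM in this assay. Compound 3 `COc1ccc(CNC(=O)/C(C#N)=C/c2ccc(Cl)o2)cc1` gives 14000 nM in this assay, the lowest number of the two read as numbers; the step from compound 1 is unreadable because of the limit of > 50000 nM in this assay, at which 1 of the 3 values shown sits, while an at least 3.5-fold lower number from compound 1 to compound 3 (0.55 log units; beyond the scatter) is an at least modest step and a 4.9-fold lower number from compound 2 to compound 3 (0.69 log units; beyond the scatter) is a modest one. Compound 4 `COc1ccc(CNC(=O)/C(C#N)=C/c2cc(Br)co2)cc1` carries the change (4-bromofuran-2-yl in place of 5-chlorofuran-2-yl on a double-bonded chain carbon bound to a double-bonded chain carbon). Within the data shown here, the only measured step that bears on a halogen on the furan is a 4.9-fold lower number from compound 2 to compound 3 (0.69 log units; beyond the scatter), and no measured pair tells what moving the halogen to the 4-position of the furan does, nor what bromo does in place of chloro. Compound 4 is therefore expected to stay near compound 3, with a 1.4-fold higher number from compound 3 to compound 4 (0.15 log units; within the scatter) as the expected step, which lies within the scatter. The estimate for compound 4 in this assay is 20000 nM, between 5000 nM and 80000 nM.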

Compound 4, concentration for 50% growth inhibition: > 100000 nM
Compound 4 was reported as a limit; the forecaster's own chance of this, stated with the estimate: 20%; at least 5.0-fold (0.69 log units) between middle value and limit.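

In this assay, putting 4-bromofuran-2-yl in place of 5-chlorofuran-2-yl on the double-bonded chain carbon gives an at least 7.1-fold higher number from compound 3 to compound 4 (0.85 log units; beyond the scatter), so the lower number of compound 3 does not carry over to every halogen furan at this place, and a halogen on the furan is not enough to keep it. Compound 4 stands only as a limit of the assay: the limit of > 100000 nM in this assay, at which 1 of the 4 values shown sits. Against the methyl furan the result reads an at least 1.4-fold higher number from compound 2 to compound 4 (0.16 log units; that floor lies within the scatter), a floor that on its own does not set compound 4 apart from compound 2, while the steps involving the limit of compound 1 that the two limits or a single limit leave open cannot be read.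

The compounds shown leave open whether the loss goes with bromo in place of chloro or with the halogen standing at the 4-position of the furan, as both change together in this one step, and a 5-bromofuran-2-yl or a 4-chlorofuran-2-yl group would pull the two apart. Also open, on these data alone, is how a furan carrying an amine or a carboxylic acid at this place would read in this assay.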